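The source may report more compounds than this note shows. Statements on the series, on what has been measured and on what is new or still open speak of the compounds shown alone.

In a functional assay on K562 cells (Homo sapiens) for antiproliferative activity, with a stated time of 72 h (a lower number here means a stronger inhibitor, a higher number a weaker inhibitor), compound 1 `COc1ccccc1CNc1ncnc2c1ncn2[C@@H]1O[C@H](CO)[C@@H](O)[C@H]1O` gives 89000 nM and compound 2 `OC[C@H]1O[C@@H](n2cnc3c(NCc4ccc(Cl)cc4Cl)ncnc32)[C@H](O)[C@@H]1O` gives 106000 nM while compound 3 `OC[C@H]1O[C@@H](n2cnc3c(NCc4cccc(O)c4O)ncnc32)[C@H](O)[C@@H]1O` gives 25800 nM as the lowest of the three numbers. Compound 4 `OC[C@H]1O[C@@H](n2cnc3c(NCc4cccc(C(F)(F)F)c4)ncnc32)[C@H](O)[C@@H]1O` is still unmeasured. It carries 3-(trifluoromethyl)phenyl in place of 2,3-dihydroxyphenyl on a saturated chain carbon bound to a nitrogen on an aromatic ring, a change counted as 3-(trifluoromethyl)phenyl in place of 2,3-dihydroxyphenyl on a saturated chain carbon bound to a nitrogen on an aromatic ring for this pair. Within the data shown here, two steps bear on it: a 3.4-fold lower number from compound 1 to compound 3 (0.54 log units; beyond the scatter) and a 4.1-fold lower number from compound 2 to compound 3 (0.61 log units; beyond the scatter) on reaching 2,3-dihydroxyphenyl, whereas the exchange between the other two groups gave only a 1.2-fold higher number from compound 1 to compound 2 (0.08 log units; within the scatter) in comparison. Losing that group, a modest upward move of similar size is expected, estimated as a 2.9-fold higher number from compound 3 to compound 4 (0.46 log units; beyond the scatter) in this assay for this change. For compound 4 the estimated value is 75000 nM with an expected range from 30000 nM to 180000 nM in this read-out.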

Compound 4, half-maximal inhibitory concentration: > 166000 nM
Compound 4: a limit, no number (the forecaster's own chance of this, stated with the estimate: 10%); middle value at least 2.2-fold (0.34 log units) away from the limit.
By their numbers in this assay, from the lowest: compound 3; then compounds 1 and 2 (each within the scatter of the next). At a limit, above all of these: compound 4.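

Compound 4 gives a limit and not a number: the limit of > 166000 nM in this assay, at which 1 of the 4 values shown sits. Exchanging 2,3-dihydroxyphenyl for 3-(trifluoromethyl)phenyl, which has 0 hydrogen-bond donors and 0 hydrogen-bond acceptors, gives an at least 6.4-fold higher number from compound 3 to compound 4 (0.80 log units; beyond the scatter), so a third group now sits clear of compound 3 at this place. The other two steps, an at least 1.5-fold higher number from compound 2 to compound 4 (0.19 log units; that floor lies within the scatter) and an at least 1.8-fold higher number from compound 1 to compound 4 (0.27 log units; that floor lies within the scatter), do not separate compound 4 from compound 2 or compound 1.

From the compounds shown here alone, it remains open whether a single hydroxyl group on the phenyl ring would keep the lower number of compound 3. Going by these compounds, how an amine or a carboxylic acid on that ring would read also remains open.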